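Trifluoromethyl for amino on the aryl ketone of the series

The source may report more compounds than this note shows. Statements on the series, on what has been measured and on what is new or still open speak of the compounds shown alone.

Three measured compounds share one core and differ only in the group on the aryl ketone ring. Compound 1 `O=C(/C=C/c1ccc2c(c1)B(O)OC2)c1ccc(-c2ccccc2)cc1` carries phenyl there, compound 2 `Cc1ccc(C(=O)/C=C/c2ccc3c(c2)B(O)OC3)cc1` methyl, compound 3 `Nc1ccc(C(=O)/C=C/c2ccc3c(c2)B(O)OC3)cc1` amino. In a functional assay on HCT-116 cells (Homo sapiens) for cytotoxicity, read by MTT assay, with a stated time of 48 h (a higher number here means a weaker inhibitor, a lower number a stronger inhibitor), compound 1 gives 9500 nM, compound 2 gives 10500 nM, and compound 3 gives 26100 nM. Compound 3 thus stands with the highest number of the three; its neighbours are a 2.5-fold higher number from compound 2 to compound 3 (0.40 log units; beyond the scatter) and a 2.7-fold higher number from compound 1 to compound 3 (0.44 log units; beyond the scatter), both modest but beyond the scatter, whereas the step of a 1.1-fold higher number from compound 1 to compound 2 (0.04 log units; within the scatter) is within the scatter.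

Compound 4 `O=C(/C=C/c1ccc2c(c1)B(O)OC2)c1ccc(C(F)(F)F)cc1` is not yet measured. Relative to compound 3 the change is trifluoromethyl in place of amino on an aromatic carbon. Among the compounds with values here, no measured step introduces trifluoromethyl, so the only bearing comes from the two steps that remove or replace amino. Both steps toward compound 3 raised the number by a modest amount, and the methyl and phenyl analogues sit together. Replacing amino with a group that carries no donor or acceptor is therefore expected to lower the number by a modest amount, on the order of those two steps, toward the level of compound 1 and compound 2. For compound 4 the estimated step is a 2.4-fold lower number from compound 3 to compound 4 (0.38 log units; beyond the scatter). For compound 4 in this assay the expected value is 11000 nM, with a range from 4000 nM to 30000 nM.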

Compound 4, half-maximal inhibitory concentration: 6300 nM
Beside the measured number, compound 4's estimate is 1.7-fold (0.24 log units) above it, within the range that was stated.
By their numbers in this assay, from the lowest: compounds 4, 1 and 2 (each within the scatter of the next); then compound 3.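

In this assay, within the data shown here, there is a 4.1-fold lower number from compound 3 to compound 4 (0.62 log units; beyond the scatter) and this is the first measured step that brings trifluoromethyl to this position, on an aromatic carbon para to a large group. Set against the other two groups, trifluoromethyl gives a 1.7-fold lower number from compound 2 to compound 4 (0.22 log units; within the scatter) and a 1.5-fold lower number from compound 1 to compound 4 (0.18 log units; within the scatter) and both steps stay within the scatter, so methyl, phenyl and trifluoromethyl cannot be told apart here and amino in compound 3 is the only one of the four groups that stands apart. Nothing measured here bears on why compound 3 differs from the other three.

The compounds shown leave open whether a hydroxyl, a dimethylamino group or a carboxylic acid at this place would fall with compound 3 or with the level of compound 1, compound 2 and compound 4. All four changes also sit at this single place on the aryl ketone ring, so the same groups elsewhere on that ring remain an open question.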